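Replacing Bromo with Methyl in a Hydroxymethyl Compound

This account rests on a few compounds, and the source may have more. Where it says the series, first, only, none or still open, it means among the compounds named here.

In a functional assay on NCI-H460 cells (Homo sapiens) for cytotoxicity, read by sulforhodamine B assay, with a stated time of 3 days (a higher number here means a weaker inhibitor, a lower number a stronger inhibitor), compound 1 `O=Cc1cn(Cc2cccc(Br)c2)c2ccccc12` gives 39 nM and compound 2 `OCc1cn(Cc2cccc(Br)c2)c2ccccc12` gives 28 nM, so compound 2 stands level with compound 1. The next structure, compound 3 `Cc1cccc(Cn2cc(CO)c3ccccc32)c1`, has methyl in place of bromo on an aromatic carbon. Among the measured compounds shown here, the only measured step, a 1.4-fold lower number from compound 1 to compound 2 (0.14 log units; within the scatter), puts hydroxymethyl in place of formyl and leaves the bromo untouched. It offers no direct guide, so no step beyond the scatter is expected in this assay. The estimate means a 1.4-fold higher number from compound 2 to compound 3 (0.15 log units; within the scatter), an expected step within the scatter. For compound 3 the expected value is 40 nM, with an estimated range of 14 nM to 115 nM.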

Compound 3, half-maximal inhibitory concentration: 31 nM
Estimate against measurement, compound 3: 1.3-fold (0.11 log units) above; low and high end bracket the measured number.
By their numbers in this assay, from the lowest: compounds 2, 3 and 1 (each within the scatter of the next).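

On an aromatic carbon of a six-membered aromatic ring of carbon only, meta to a large group, methyl can take the place of bromo in this assay with a 1.1-fold higher number from compound 2 to compound 3 (0.04 log units; within the scatter) as the result. The bromine of compound 2 is therefore not needed for a number of this size, at least alongside the hydroxymethyl. Nothing available explains why the two groups read alike.

As far as these compounds go, whether an amine, a carboxylic acid or a longer chain would hold the number at this position remains open. So does whether the same change would read alike with the formyl of compound 1.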